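Swapping one halogen on the benzyl group of compound 3

This account rests on a few compounds, and the source may have more. Where it says the series, first, only, none or still open, it means among the compounds named here.

Measured so far in a functional assay on L1210 cells (Mus musculus), with a stated time of 48 h; a higher number here means a weaker inhibitor, a lower number a stronger inhibitor:
compound 1 `O=C1Nc2ccc(Cl)cc2/C1=N/NC(=S)Nc1ccc(Cl)cc1`: 108000 nM
compound 2 `O=C1/C(=N\NC(=S)Nc2ccc(Cl)cc2)c2cc(F)ccc2N1Cc1ccc(F)cc1`: 154000 nM
compound 3 `O=C1/C(=N\NC(=S)Nc2ccc(Cl)cc2)c2cc(Cl)ccc2N1Cc1ccc(Cl)cc1`: 124000 nM

All three compounds share the same core and all three sit close together in this assay. Compound 3 gives the second highest of the three numbers. Its nearest neighbour is compound 1, and the step from compound 1 to compound 3 is a 1.1-fold higher number from compound 1 to compound 3 (0.06 log units; within the scatter), so the added 4-chlorobenzyl group makes no difference that the assay can resolve. Compound 2 stands a little higher than compound 3, but the two differ in two places at once, so their values alone are what can be said.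

Compound 4 `O=C1/C(=N\NC(=S)Nc2ccc(Cl)cc2)c2cc(Cl)ccc2N1Cc1ccc(F)cc1` differs from compound 3 by fluoro in place of chloro on an aromatic carbon. Within the data shown here, no measured step exchanges fluoro for chloro at that position, so nothing directly bears on it. Among the measured compounds shown here, the only single-site step available, from compound 1 to compound 3, showed that changes on this benzyl side of the molecule leave the number where it was, and compound 2, which carries fluoro on both outer rings, is not far from compound 3 either. The expected step in this assay from compound 3 to compound 4 is therefore no change at the digits printed from compound 3 to compound 4 (within the scatter), nothing beyond the scatter. Compound 4 is estimated at 124000 nM, within a range from 62000 nM to 248000 nM.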

Compound 4, half-maximal inhibitory concentration: 103000 nM
Estimate against measurement, compound 4: 1.2-fold (0.08 log units) above; measured number inside the range.
By their numbers in this assay, from the lowest: compounds 4, 1, 3 and 2 (each within the scatter of the next).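

In this assay, exchanging chloro for fluoro on the benzyl group gives a 1.2-fold lower number from compound 3 to compound 4 (0.08 log units; within the scatter), so the assay cannot tell these two halogens apart at this position on the ring. Compound 4 also allows two further single-place readings: changing the halogen on the shared core, with the 4-fluorobenzyl group held constant, gives a 1.5-fold lower number from compound 2 to compound 4 (0.17 log units; within the scatter), and placing 4-fluorobenzyl on the amide-type nitrogen in place of hydrogen gives a 1.0-fold lower number from compound 1 to compound 4 (0.02 log units; within the scatter), so neither the core halogen nor the fluorinated benzyl group shows an effect that can be resolved, just as 4-chlorobenzyl showed none. Nothing available explains why these changes leave the number within the scatter.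

These compounds compare only hydrogen, chloro and fluoro at the sites that vary, so they do not show whether this flat picture would hold for a different kind of group. A methoxy group or a carboxylic acid on the benzyl ring, or a longer chain in place of the benzyl group on the nitrogen, remains an open case.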